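The source may hold more compounds than are shown below. What is called first, only, known or untested is meant among the compounds shown, and "the series" means these compounds.

In a functional assay on HCT-8 cells (Homo sapiens) for antiproliferative activity, read by MTT assay, with a stated time of 48 h (on this read-out lower numbers stand for stronger inhibition and higher numbers for weaker inhibition), compound 1 `COc1ccc2c(/C=C/C(=O)c3cc(N)c(OC)c(OC)c3)c[nH]c2c1` gives 368 nM, compound 2 `COc1ccc2c(/C=C(\C)C(=O)c3cc(OC)c(OC)c([Se]C)c3)cn(C)c2c1` gives 25 nM and compound 3 `COc1ccc2c(/C=C(\C)C(=O)c3cc(OC)c(OC)c([Se]C)c3)c[nH]c2c1` gives 29 nM. Compound 3 therefore sits level with compound 2, within the scatter of repeated measurements, and its number is far lower than that of compound 1, which means much stronger inhibition.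

The next compound is compound 4 `COc1cc(C(=O)/C(C)=C/c2c[nH]c3ccccc23)cc([Se]C)c1OC`. It has hydrogen in place of methoxy on an aromatic carbon of the six-membered aromatic ring of carbon only that is part of the fused system: hydrogen in place of methoxy on an aromatic carbon.

Only one measured step links two of these compounds by a single change: a 1.2-fold higher number from compound 2 to compound 3 (0.06 log units; within the scatter), with hydrogen in place of methyl on an aromatic nitrogen. That step lies within the scatter, but it concerns another place in the molecule, so it gives only weak guidance here. For the measured compounds named here, no measured pair shows this methoxy leaving, so the size of the new step is uncertain.

A moderate loss of strength seems the more likely outcome, and the expected change is a 2.4-fold higher number from compound 3 to compound 4 (0.38 log units; beyond the scatter). The range is kept wide on the upper side, since compound 1 at 368 nM shows that much higher numbers occur among these compounds. Compound 4 is estimated at 70 nM, with an expected range of 20 nM to 250 nM.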

Compound 4, half-maximal inhibitory concentration: 32 nM
Estimate against measurement, compound 4: 2.2-fold (0.34 log units) above; the range from low to high includes it.
By their numbers in this assay, from the lowest: compounds 2, 3 and 4 (each within the scatter of the next); then compound 1.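

In this assay, hydrogen in place of methoxy on this aromatic carbon of the fused system gives a 1.1-fold higher number from compound 3 to compound 4 (0.04 log units; within the scatter), so compound 3 and compound 4 stand level and this methoxy is not needed to keep the number in this range. For the compounds shown here, this is the first measured look at this place in the molecule, and it adds a second single change to the shared core that stays within the scatter, alongside a 1.2-fold higher number from compound 2 to compound 3 (0.06 log units; within the scatter), which concerns the aromatic nitrogen instead. Nothing available here explains why removing the methoxy leaves the number level.

With only methoxy and hydrogen shown on this carbon, it remains open whether the place tolerates any group at all or only these two, and an amine, a carboxylic acid or a longer chain such as butoxy could give a very different number. It is also open whether the level result would hold with methyl on the aromatic nitrogen, since the compounds shown do not combine that methyl with hydrogen on this carbon.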